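The compounds below may be only part of what the source reports. "The series", "measured", "known", "first", "only" and "open" are said of these compounds alone.

Of the compounds shown here, two built on one shared core have been tested in a functional assay on HOP-62 cells (Homo sapiens) for inhibition, read by sulforhodamine B assay, with a stated time of 48 h; on this read-out lower numbers stand for higher toxicity in this test and higher numbers for lower toxicity in this test. Compound 1, `Cc1cc(O)cc(-c2nn(CC#N)cc2-c2ccnc(-c3ccc(Oc4ccccc4)cc3)c2)c1`, carries a hydroxy group and a phenoxyphenyl group, and in this assay compound 1 gives 52300 nM. Compound 2, `COc1cc(C)cc(-c2nn(CC#N)cc2-c2ccnc(-c3ccc(N(C)C)cc3)c2)c1`, instead carries a methoxy group and a dimethylaminophenyl group. For compound 2 the result in this assay is a limit, > 100000 nM, and not a number. For the measured compounds named here, compound 1 and compound 2 differ at two places, so their two values show only that compound 1 sits inside the measured window while compound 2 sits at the limit of > 100000 nM in this assay, at which 1 of the 2 values shown sits.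

Compound 3, `Cc1cc(O)cc(-c2nn(CC#N)cc2-c2ccnc(-c3ccc(N(C)C)cc3)c2)c1`, keeps the dimethylaminophenyl group of compound 2, and the change is hydrogen in place of methyl on an oxygen on an aromatic ring. Going by the values given here, no measured pair shows this change on its own. The step in this assay is therefore expected to be small, none beyond the scatter, with the direction left open. Compound 3 is estimated at 80000 nM in this assay, with a range from 30000 nM to 200000 nM. This estimate means an at least 1.2-fold lower number from compound 2 to compound 3 (0.09 log units; that floor lies within the scatter).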

Compound 3, concentration lethal to 50% of the cells: > 100000 nM
Compound 3: no number, only a limit; the forecaster's own chance of this, stated with the estimate: 50%; middle value at least 1.2-fold (0.09 log units) away from the limit.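

For the compounds shown here, compound 3 gives the first comparison that changes only one place: with dimethylamino in place of phenoxy on an aromatic carbon and the hydroxy group kept, this assay shows an at least 1.9-fold higher number from compound 1 to compound 3 (0.28 log units; that floor lies within the scatter). This figure is only a floor, since the result for compound 3 is a limit and not a number, so the pair does not yet establish a difference beyond the usual scatter. The step for hydrogen in place of methyl on the oxygen cannot be read, and methoxy to hydroxy leaves the dimethylaminophenyl compounds, compound 2 and compound 3, together at the limit of the test: the limit of > 100000 nM in this assay, at which 2 of the 3 values shown sit.

The compounds shown leave open whether methoxy and hydroxy differ at all in a compound that gives a real number, as a methoxy partner of compound 1 with its phenoxyphenyl group could show. They also leave open how a longer chain on that oxygen, such as ethoxy, or a carboxylic acid in place of the dimethylamino group would read.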